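This account rests on a few compounds, and the source may have more. Where it says the series, first, only, none or still open, it means among the compounds named here.

Measured in a functional assay on MT4 cells (Homo sapiens) for cytotoxicity, read by CellTiter-Glo, with a stated time of 5 days; on this read-out lower numbers stand for an effect already at smaller amounts and higher numbers for an effect only at larger amounts of compound:
- compound 1 `Cc1ccc(-c2c(C)noc2CO)cc1S(=O)(=O)NC1CCCC1`: 6820 nM
- compound 2 `Cc1noc(C)c1-c1cc(S(=O)(=O)NC2CCCC2)c2cc(N3CCCC3)c(=O)[nH]c2c1`: 140 nM
- compound 3 `Cc1ccc(-c2cnoc2)cc1S(=O)(=O)NC1CCCC1`: 43200 nM

Compound 3 has the highest number of the three, meaning its effect on the cells appears only at the largest amounts. Its nearest neighbour on the scale is compound 1, and compound 2 lies furthest away.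

The next compound, compound 4 `Cc1ccc(-c2cnoc2C)cc1S(=O)(=O)NC1CCCC1`, differs from compound 3 by a single small change: methyl in place of hydrogen on an aromatic carbon. This is methyl in place of hydrogen on an aromatic carbon, next to the ring oxygen.

Going by the values given here, only one measured step bears on this change: a 6.3-fold higher number from compound 1 to compound 3 (0.80 log units; beyond the scatter). There, the smaller group of compound 3 replaces the larger group of compound 1, and the number rises. Among the compounds with values here, compound 4 gains only a little of that lost size, and no measured pair shows the effect of a methyl alone. A slightly lower number is therefore expected, with no step beyond the scatter.

The expected change is a 1.7-fold lower number from compound 3 to compound 4 (0.24 log units; within the scatter). For compound 4, the estimate is 25000 nM, within an expected range of 9000 nM to 55000 nM.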

Compound 4, half-maximal effective concentration: 15100 nM
Estimate against measurement, compound 4: 1.7-fold (0.22 log units) above; the measured number falls inside the stated range.
By their numbers in this assay, from the lowest: compound 2; then compound 1; then compound 4; then compound 3.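

In this assay, going by these compounds alone, one added methyl on the aromatic carbon next to the ring oxygen is enough to move the result, with a 2.9-fold lower number from compound 3 to compound 4 (0.46 log units; beyond the scatter) on the scale, something no earlier pair could show for a methyl alone. The methyl covers only part of the distance to the larger group at this place, and with a 2.2-fold higher number from compound 1 to compound 4 (0.35 log units; beyond the scatter) on the scale a gap beyond the usual scatter remains. Nothing measured here gives a reason for either shift.

Still open, going by these compounds, is whether an ethyl, a longer chain or an amine on this same carbon would lower the number further or raise it again. Also open, on these data alone, is whether the methyl would shift the number by a similar amount on a different core.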